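The compounds below may be only part of what the source reports. "The series", "measured", "known", "first", "only" and "open" are said of these compounds alone.

- compound 1 `CCCCOc1cccc(C(=O)/C=C/c2ccc(OC)cc2OC)c1`: 65000 nM
- compound 2 `COc1cc(/C=C/C(=O)c2cccc(N(C)C)c2)cc(OC)c1`: 5000 nM

In a functional assay (Homo sapiens) for inhibition (on this read-out higher numbers stand for weaker inhibition and lower numbers for stronger inhibition), compound 1 gives 65000 nM, the highest of the two numbers, and compound 2, which carries no butoxy, gives 5000 nM, a gap beyond the scatter. Compound 3 `COc1ccc(/C=C/C(=O)c2cccc(Br)c2)c(OC)c1` has not been measured. It differs from compound 1 by bromo in place of butoxy on an aromatic carbon, with bromo in place of butoxy on an aromatic carbon. Within the data shown here, no measured pair shows this change, so the expectation is tentative. The expected step is a 3.3-fold lower number from compound 1 to compound 3 (0.51 log units; beyond the scatter), toward a lower number and stronger inhibition. For compound 3, the estimated value is 20000 nM, with an expected range of 5000 nM to 80000 nM.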

Compound 3, half-maximal inhibitory concentration: 37000 nM
Compound 3: middle estimate off by 1.9-fold (0.27 log units), on the low side, and the stated range covers the measured number.
By their numbers in this assay, from the lowest: compound 2; then compounds 3 and 1 (each within the scatter of the next).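

In this assay the exchange of butoxy for bromo on an aromatic carbon, meta to a large group, amounts to a 1.8-fold lower number from compound 1 to compound 3 (0.24 log units; within the scatter) and so the read-out does not separate these two groups at this position. The position therefore accepts the loss of the whole butoxy chain, with its hydrogen-bond acceptor, without a change beyond the scatter. Nothing at hand gives a reason for this. Still open, going by these compounds, is whether an amine, a carboxylic acid or a longer chain at this position would move the number beyond the scatter.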